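Configuration change from compound 2: expectation for compound 4

The source may hold more compounds than are shown below. What is called first, only, known or untested is meant among the compounds shown, and "the series" means these compounds.

In a functional assay on RAW264.7 cells (Mus musculus) for inhibition, read by Griess assay, with stated times of 2 h and 20 h (on this read-out lower numbers stand for stronger inhibition and higher numbers for weaker inhibition), compound 1 (`COC1=C(C)C(=O)C2=C(O[C@]3(CC[C@@H]4C[C@@H]3C4(C)C)C[C@@H]2C(C)C)C1(C)C`) gives 3700 nM and compound 3 (`COC1=C(C)C(=O)[C@@]2(CC=C(CCC=C(C)C)C[C@H]2C(C)C)C(=O)C1(C)C`) gives 2070 nM. Compound 2 (`COC1=C(C)C(=O)C2=C(O[C@]3(CC[C@]45[C@H]([C@H](C(C)C)CC[C@H]4C)[C@@H]35)C[C@H]2C(C)C)C1(C)C`) gives 30500 nM, the highest number of the three and beyond the scatter from both others. Compound 4 (`COC1=C(C)C(=O)C2=C(O[C@@]3(CC[C@]45[C@H]([C@H](C(C)C)CC[C@H]4C)[C@@H]35)C[C@@H]2C(C)C)C1(C)C`) differs from compound 2 only in configuration: the two compounds have the same atoms and bonds and differ only in configuration as drawn: 2 of 7 stereo elements differ; a stereocentre at a saturated ring carbon is drawn R in compound 2 and S in compound 4; a stereocentre at a saturated ring carbon is drawn S in compound 2 and R in compound 4. Going by the values given here, no measured pair shows what such a change does, so the expectation is loose. With compound 2 at 30500 nM, the top of the measured range, a moderate move towards stronger inhibition is expected rather than a further rise. The expected change is a 2.2-fold lower number from compound 2 to compound 4 (0.34 log units; beyond the scatter). For compound 4 the estimate is 14000 nM, with an expected range of 4000 nM to 45000 nM.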

Compound 4, half-maximal inhibitory concentration: 15200 nM
Compound 4: the middle estimate sits 1.1-fold (0.04 log units) below what was measured; low and high end bracket the measured number.
By their numbers in this assay, from the lowest: compounds 3 and 1 (each within the scatter of the next); then compounds 4 and 2 (each within the scatter of the next).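

In this assay, the only pair shown that differs in one place gives a 2.0-fold lower number from compound 2 to compound 4 (0.30 log units; within the scatter), so inverting these two saturated ring stereocentres, one drawn R to S and the other S to R, leaves the number within the scatter. This is the first direct reading of a configuration change in the series, and no other structural difference enters the comparison: the fact that compounds 2 and 4 differ only in the configuration as drawn

From the compounds shown here alone, what each stereocentre does alone stays open. So does whether the same inversion stays this small with an amine or a carboxylic acid on the shared core.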